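Series notes: nitro in place of hydrogen, cytotoxicity expectation

This account rests on a few compounds, and the source may have more. Where it says the series, first, only, none or still open, it means among the compounds named here.

Of the compounds shown here, two sharing the same core have been measured in a functional assay on EC9706 cells (Homo sapiens) for cytotoxicity, read by MTT assay, with a stated time of 72 h; a higher number here means a weaker inhibitor, a lower number a stronger inhibitor. Compound 1 `O=C(CSC(=S)N[C@H]1CCOC1=O)Nc1ccc(C(=O)/C=C/c2ccc(Cl)cc2)cc1` gives 38900 nM in this assay. Compound 2 `O=C(CSC(=S)N[C@H]1CCOC1=O)Nc1ccc(C(=O)/C=C/c2ccccc2)cc1` gives 44900 nM in this assay. Among the measured compounds shown here, the one step that links them, a 1.2-fold higher number from compound 1 to compound 2 (0.06 log units; within the scatter), replaces chloro by hydrogen on an aromatic carbon and lies within the scatter, so the two numbers cannot be told apart. For the measured compounds named here, compound 2 stands at the upper end of the two numbers; its only neighbour is compound 1, and the gap between them is within the scatter.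

Compound 3 `O=C(CSC(=S)N[C@H]1CCOC1=O)Nc1ccc(C(=O)/C=C/c2ccc([N+](=O)[O-])cc2)cc1` differs from compound 2 by nitro in place of hydrogen on an aromatic carbon of a six-membered aromatic ring of carbon only, para to a large group. Going by the values given here, the only measured step that bears on this change is a 1.2-fold higher number from compound 1 to compound 2 (0.06 log units; within the scatter), which touched the same place and stayed within the scatter. No step beyond the scatter is therefore expected in this assay for compound 3, and its number is estimated at 40000 nM, in the range 15000 nM to 110000 nM, a step of a 1.1-fold lower number from compound 2 to compound 3 (0.05 log units; within the scatter) that is expected to remain within the scatter.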

Compound 3, half-maximal inhibitory concentration: > 128000 nM
Compound 3 ended at the assay's limit; the forecaster's own chance of this, stated with the estimate: 15%; middle value at least 3.2-fold (0.50 log units) from the limit.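

In this assay the value of compound 3 is a limit of the assay and not a number: the limit of > 128000 nM in this assay, at which 1 of the 3 values shown sits.

Even so, this aromatic position, para to a large group, does not tolerate every substituent equally. Nitro in place of hydrogen gives an at least 2.8-fold higher number from compound 2 to compound 3 (0.45 log units; beyond the scatter) and nitro in place of chloro gives an at least 3.2-fold higher number from compound 1 to compound 3 (0.51 log units; beyond the scatter), whereas the exchange of chloro and hydrogen stayed within the scatter (a 1.2-fold higher number from compound 1 to compound 2 (0.06 log units; within the scatter)). Among the three compounds, the only readable shift in this assay therefore comes with the nitro group of compound 3, and compound 1 and compound 2 cannot be told apart; both steps to compound 3 are bounded on one side only, so their full size stays unknown.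

Open, as far as these compounds go, is whether the weakening belongs to nitro alone or also appears with other groups at this place, such as a nitrile, a methoxy group or an amine. Also open, from the compounds shown here alone, is whether nitro on another carbon of the same ring would give a comparable step.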